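Removing the bromo from compound 1

The source may hold more compounds than are shown below. What is called first, only, known or untested is meant among the compounds shown, and "the series" means these compounds.

Measured so far in a functional assay on A549 cells (Homo sapiens) for cytotoxicity, read by MTT assay, with a stated time of 72 h; on this read-out lower numbers stand for stronger inhibition and higher numbers for weaker inhibition:
- compound 1 `CNC(=O)c1cc(Oc2ccc(NC(=O)c3cc(-c4ccc(Br)cc4)ncn3)cc2)ccn1`: > 100000 nM (a limit)
- compound 2 `CNC(=O)c1cc(Oc2ccc(NC(=O)c3nccc(-c4cccc(Cl)c4)n3)cc2)ccn1`: > 100000 nM (a limit)
- compound 3 `CNC(=O)c1cc(Oc2ccc(NC(=O)c3cc(-c4ccc(Br)cc4)ncn3)cc2F)ccn1`: > 100000 nM (a limit)

Compound 1 gives only a limit, > 100000 nM, so it has no numerical place in the series. The whole set rests on (the limit of > 100000 nM in this assay, at which 3 of the 3 values shown sit).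

The change to compound 4 `CNC(=O)c1cc(Oc2ccc(NC(=O)c3cc(-c4ccccc4)ncn3)cc2)ccn1` is hydrogen in place of bromo on an aromatic carbon. It lies on an aromatic carbon of a six-membered aromatic ring of carbon only, para to a large group, and turns 4-bromophenyl into phenyl.

Among the compounds with values here, the one measured step is a step that the two limits leave unreadable from compound 1 to compound 3, with fluoro in place of hydrogen on an aromatic carbon. It is a different change and offers no size to carry over. Given that compound 1 sits at the limit of > 100000 nM in this assay, at which 3 of the 3 values shown sit, no step beyond the scatter is expected in this assay, and no direction can be assigned. The expected outcome is a number no higher from compound 1 to compound 4 (the limit leaves the size open). For compound 4 the estimated value is 100000 nM, with an expected range from 30000 nM to 150000 nM.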

Compound 4, half-maximal inhibitory concentration: 27100 nM
The estimate for compound 4 lay 3.7-fold (0.57 log units) above the measured number; the measured number lies below the stated range.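

In this assay, this place on the six-membered aromatic ring of carbon only is where the series first gives a readable change: hydrogen in place of bromo gives an at least 3.6-fold lower number from compound 1 to compound 4 (0.56 log units; beyond the scatter). The earlier compounds shown here showed no such change, and the step from compound 1 to compound 3 cannot be read, as both ends are limits. Compound 4 is the only compound shown with a number, while the step stays a bound with its full size open: the limit of > 100000 nM in this assay, at which 3 of the 4 values shown sit.

Going by these compounds, whether a chloro, a methoxy or an amine at this place would keep the number of compound 4 or return to the limit stays open. So does what the fluoro of compound 3 would do on compound 4, which has no bromo.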